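Swapping the ring on the side chain of compound 2

The source may hold more compounds than are shown below. What is called first, only, known or untested is meant among the compounds shown, and "the series" means these compounds.

Measured so far:
compound 1, `O=C1O/C(=C\Cn2ncc(=O)[nH]c2=O)C(OCc2ccccc2)=C1OCc1ccccc1`, 24600 nM
compound 2, `Nc1ccn(C[C@H](O)[C@H]2OC(=O)C(OCc3ccccc3)=C2OCc2ccccc2)c(=O)n1`, 53900 nM
compound 3, `O=C1O[C@H]([C@@H](O)Cn2ccc(NC(=O)c3ccccc3)nc2=O)C(OCc2ccccc2)=C1OCc1ccccc1`, 8820 nM

In an ADME assay on WI-38 cells (Homo sapiens) for inhibition, read by MTT assay, with a stated time of 72 h (on this read-out higher numbers stand for weaker inhibition and lower numbers for stronger inhibition), compound 2 gives the highest number of the three; compound 1 sits somewhat lower, and compound 3 lower still. Among the measured compounds shown here, the one step among measured compounds that differ in a single place is a 6.1-fold lower number from compound 2 to compound 3 (0.79 log units; beyond the scatter), where a benzoyl replaces a hydrogen on a nitrogen of the aromatic ring.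

Compound 4, `O=C1O[C@H]([C@@H](O)Cn2c(=O)[nH]c(=O)[nH]c2=O)C(OCc2ccccc2)=C1OCc1ccccc1`, has not yet been measured. It differs from compound 2 as follows: a group of 9 heavy atoms (3 carbon, 3 nitrogen, 3 oxygen; one six-membered aromatic ring with 3 hetero atoms) in place of a group of 8 heavy atoms (4 carbon, 3 nitrogen, 1 oxygen; one six-membered aromatic ring with 2 hetero atoms), on a saturated chain carbon, two bonds along the chain from an oxygen on a saturated carbon and a saturated ring carbon. For the measured compounds named here, no measured pair shows this kind of change. The step from compound 2 to compound 3 changes a substituent on the ring rather than the ring itself, so it bears only loosely on the question. Compound 1 carries a ring with two hetero atoms in the same part of the molecule but also lacks the hydroxyl and has a different linkage, so its value can only be read as a rough guide.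

Going by the values given here, with no direct precedent, compound 4 is expected to stay close to compound 2 in this assay, with any step most likely within the scatter, and the estimate is 40000 nM, in the range 15000 nM to 100000 nM, which means an expected step of a 1.3-fold lower number from compound 2 to compound 4 (0.13 log units; within the scatter).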

Compound 4, half-maximal inhibitory concentration: > 100000 nM
Compound 4: only a limit was reported; the forecaster's own chance of this, stated with the estimate: 10%; at least 2.5-fold (0.39 log units) between middle value and limit.
By their numbers in this assay, from the lowest: compound 3; then compound 1; then compound 2. At a limit, above all of these: compound 4.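

In this assay compound 4 reaches only a limit of the assay and not a number: the limit of > 100000 nM in this assay, at which 1 of the 4 values shown sits. Exchanging the ring group on the saturated chain carbon, rather than changing a substituent on the ring as in a 6.1-fold lower number from compound 2 to compound 3 (0.79 log units; beyond the scatter), gives an at least 1.8-fold higher number from compound 2 to compound 4 (0.26 log units; that floor lies within the scatter), and this figure is a floor, so the true size of the step cannot be read from it. Among the compounds shown here, what the result adds is that the ring itself can be changed at this place, here to a six-membered aromatic ring with 3 hetero atoms, without the number falling below that of compound 2, whereas the only earlier step at this end of the molecule had lowered it.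

As far as these compounds go, how far the number of compound 4 lies past the limit stays open, as does whether a benzoyl on the new ring would lower its number as it does for compound 3. Also open is what a methyl group, a fluorine or an amine on the ring of compound 4 would give, since the compounds shown cover only one ring exchange at this place.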